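A few compounds are considered here, and "the series" means these few. Any claim that something is new, unique, unknown or untested is made for them only; others in the source may bear on it.

Measured in a toxicity assay on MT2 cells (Homo sapiens) for cytotoxicity, read by XTT assay, with a stated time of 4 days; a lower number here means that less compound is tolerated, a higher number that more compound is tolerated:
- Compound 1 `Cc1nc(C)c([C@H](OC(C)(C)C)C(=O)O)c(N2CCC(C)(C)CC2)c1-c1ccc(OCCc2ccc(F)cc2F)cc1`: >= 33500 nM
- Compound 2 `Cc1ccc(CCOc2ccc(-c3c(C)nc(C)c([C@H](OC(C)(C)C)C(=O)O)c3N3CCC(C)(C)CC3)cc2)s1`: >= 25000 nM
- Compound 3 `Cc1nc(C)c([C@H](OC(C)(C)C)C(=O)O)c(N2CCC(C)(C)CC2)c1-c1ccc(OCCc2cccnc2)cc1`: >= 25000 nM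

Each of these three values is a limit and not a number. Compound 3 thus stands only at a limit, >= 25000 nM.

Compound 4 `Cc1nc(C)c(CCOc2ccc(-c3c(C)nc(C)c([C@H](OC(C)(C)C)C(=O)O)c3N3CCC(C)(C)CC3)cc2)s1` carries 2,4-dimethyl-1,3-thiazol-5-yl in place of pyridin-3-yl on a saturated chain carbon, two bonds along the chain from an oxygen on an aromatic ring.

Three measured changes at this place bear on it: a step that the two limits leave unreadable from compound 1 to compound 2, a step that the two limits leave unreadable from compound 1 to compound 3 and a step that the two limits leave unreadable from compound 2 to compound 3. None has a readable size, and all three compounds are tolerated up to their limits, so no step beyond the scatter is expected in this assay. The expected change is a step that the limit leaves unreadable from compound 3 to compound 4. For compound 4 the estimate is 28000 nM, with an expected range from 12000 nM to 50000 nM.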

Compound 4, half-maximal cytotoxic concentration: >= 25000 nM
Compound 4: only a limit was reported (the forecaster's own chance of this, stated with the estimate: 75%); the middle value does not contradict the limit.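

In this assay, going by these compounds alone, compound 4 gives >= 25000 nM, a limit and not a number, so no step linking it to compound 1, compound 2 or compound 3 can be read. The compounds shown leave open whether these groups on the chain differ at all in this read-out.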